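Adding an Ethyl Chain in Place of an Amide Hydrogen

This account rests on a few compounds, and the source may have more. Where it says the series, first, only, none or still open, it means among the compounds named here.

Three measured compounds share one core and differ only in the group carried on an amide-type nitrogen. Compound 1 `CCCCNC(=O)N1CC1C#N` bears a butyl chain there, compound 2 `CC(C)(C)NC(=O)N1CC1C#N` a tert-butyl group, and compound 3 `N#CC1CN1C(N)=O` a bare hydrogen. In a functional assay on OVCAR-3 cells (Homo sapiens) for inhibition (a lower number here means a stronger inhibitor, a higher number a weaker inhibitor), compound 1 gives 12000 nM. In this assay compound 2 gives 186000 nM. In this assay compound 3 gives > 90000 nM, which is a limit of the assay rather than a measured number. Compound 3 thus sits at the weak edge of what has been seen, and a step that the limit leaves unreadable from compound 2 to compound 3.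

Compound 4 `CCNC(=O)N1CC1C#N` differs from compound 3 by ethyl in place of hydrogen on an amide-type nitrogen. Within the data shown here, the one readable step at this nitrogen is the loss on removing the butyl chain, an at least 7.5-fold higher number from compound 1 to compound 3 (0.87 log units; beyond the scatter), whereas the branched group moved the other way, a 16-fold higher number from compound 1 to compound 2 (1.19 log units; beyond the scatter). A short straight chain is expected to recover part of the butyl advantage, so an at least 1.8-fold lower number from compound 3 to compound 4 (0.25 log units; that floor lies within the scatter) is the expected step. Compound 4 is therefore estimated to give 50000 nM in this assay, expected to fall between 15000 nM and 200000 nM.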

Compound 4, half-maximal inhibitory concentration: 14000 nM
Compound 4: middle estimate off by 3.6-fold (0.55 log units), on the high side; the measured number lies below the stated range.
By their numbers in this assay, from the lowest: compounds 1 and 4 (each within the scatter of the next); then compound 2.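

Ethyl in place of hydrogen on this nitrogen gives an at least 6.4-fold lower number from compound 3 to compound 4 (0.80 log units; beyond the scatter) in this assay and so a chain as short as ethyl already brings the gain. Butyl and ethyl cannot be told apart, with a 1.2-fold higher number from compound 1 to compound 4 (0.07 log units; within the scatter) as the step, whereas the change to ethyl from the branched group gives a 13-fold lower number from compound 2 to compound 4 (1.12 log units; beyond the scatter) and so branching, not chain length, is what separates these compounds. The first of these steps is only a floor, because compound 3 carries a limit of the assay and not a measured number: the limit of > 90000 nM in this assay, at which 1 of the 4 values shown sits.

Still open, as far as these compounds go, is whether a methyl group on this nitrogen would already bring the same gain. Also open, from the compounds shown here alone, is whether a longer chain such as hexyl would hold this level, and whether isopropyl would carry part of the tert-butyl loss.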